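A few compounds are considered here, and "the series" means these few. Any claim that something is new, unique, unknown or untested is made for them only; others in the source may bear on it.

Compound 1 `Cc1nnc(SCc2ccccc2Cl)n1N1C(=O)c2ccccc2C1=O` — in a functional assay on HepG2 cells (Homo sapiens) for cytotoxicity, read by MTT assay, with a stated time of 48 h (a higher number here means a weaker inhibitor, a lower number a stronger inhibitor), compound 1 gives > 200000 nM, a limit of the assay.
Compound 2 `CCCc1nnc(SCc2ccccc2Cl)n1N1C(=O)c2ccccc2C1=O` — in this assay compound 2 gives > 200000 nM, likewise a limit.
Compound 3 `C=CCSc1nnc(-c2cc(OC)c(OC)c(OC)c2)n1N1C(=O)c2ccccc2C1=O` — in this assay compound 3 gives > 200000 nM, again a limit.

Compound 3 therefore stands at the limit, as do both other measured compounds (the limit of > 200000 nM in this assay, at which 3 of the 3 values shown sit). Going by the values given here, the only measured step, a step that the two limits leave unreadable from compound 1 to compound 2, cannot be read and concerns a different position from the one changed here. Compound 4 `COc1cc(-c2nnc(SCc3ccccc3Cl)n2N2C(=O)c3ccccc3C2=O)cc(OC)c1OC` differs from compound 3 by 2-chlorophenyl in place of vinyl on a saturated chain carbon bound to a sulfur. Among the compounds with values here, no measured step bears on this change, so the expected step that the limit leaves unreadable from compound 3 to compound 4 is taken as none beyond the scatter, with compound 4 most likely reported at the same limit. Compound 4 is estimated at 250000 nM, range 100000 nM to 1000000 nM.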

Compound 4, half-maximal inhibitory concentration: > 200000 nM
Compound 4: no number, only a limit; the forecaster's own chance of this, stated with the estimate: 85%; the middle value is on the limit's open side.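

In this assay, going by these compounds alone, compound 4 gives the limit > 200000 nM and so no step from compound 1, compound 2 or compound 3 to compound 4 can be read. Whether any change to the shared core gives a readable value in this assay stays open among the compounds shown.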